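Fluoro on the central aryl ring of compound 1

The source may hold more compounds than are shown below. What is called first, only, known or untested is meant among the compounds shown, and "the series" means these compounds.

Compound 1 `Cc1cc(=O)n(-c2ccccc2OC(F)(F)F)nc1C(=O)Nc1ccc(Oc2ncnc3[nH]ccc23)cc1` sits at the top of the numbers in hand: in a functional assay on PC-3 cells (Homo sapiens) for cytotoxicity, read by MTT assay, with a stated time of 72 h (on this read-out higher numbers stand for weaker inhibition and lower numbers for stronger inhibition), compound 1 gives 22500 nM. The two neighbours that vary the aryl group on the aromatic nitrogen are compound 2 `Cc1cc(=O)n(-c2ccc(Br)cc2F)nc1C(=O)Nc1ccc(Oc2ncnc3[nH]ccc23)cc1`, which in this assay gives 2730 nM, and compound 3 `Cc1cc(=O)n(-c2cccc(C(F)(F)F)c2)nc1C(=O)Nc1ccc(Oc2ncnc3[nH]ccc23)cc1`, which in this assay gives 3460 nM. Both steps point the same way: an 8.2-fold lower number from compound 1 to compound 2 (0.92 log units; beyond the scatter) and a 6.5-fold lower number from compound 1 to compound 3 (0.81 log units; beyond the scatter); the gap between them, a 1.3-fold higher number from compound 2 to compound 3 (0.10 log units; within the scatter), stays within the scatter.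

Compound 4 `Cc1cc(=O)n(-c2ccccc2OC(F)(F)F)nc1C(=O)Nc1ccc(Oc2ncnc3[nH]ccc23)c(F)c1` keeps the aryl group on the aromatic nitrogen of compound 1 and changes elsewhere: fluoro in place of hydrogen on an aromatic carbon. For the measured compounds named here, none of the measured steps touches this part of the shared core; each of them swaps the aryl group on the aromatic nitrogen, so they bear on the step from compound 1 to compound 4 only in setting the starting point. Going by the values given here, with no step of this kind measured, no shift beyond the scatter is expected in this assay, in either direction. The expected step is therefore a 1.1-fold lower number from compound 1 to compound 4 (0.05 log units; within the scatter). For compound 4 in this assay the estimate is 20000 nM, with a range from 7000 nM to 60000 nM.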

Compound 4, half-maximal inhibitory concentration: > 60000 nM
Compound 4: a limit, no number (the forecaster's own chance of this, stated with the estimate: 15%); middle value at least 3.0-fold (0.47 log units) away from the limit.
By their numbers in this assay, from the lowest: compounds 2 and 3 (each within the scatter of the next); then compound 1. At a limit, above all of these: compound 4.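

In this assay compound 4 gives > 60000 nM, which is a limit of the assay and not a number. The aryl group on the aromatic nitrogen is therefore not the only place in this series that moves the read-out: fluoro in place of hydrogen on an aromatic carbon, ortho to a large group and meta to a large group, gives an at least 2.6-fold higher number from compound 1 to compound 4 (0.42 log units; beyond the scatter), the only step shown that lies beyond the scatter toward a higher number. This single heavy atom on the shared core thus has an effect in the same range as the aryl swaps or larger, though only a lower bound on the size of the step can be read: the limit of > 60000 nM in this assay, at which 1 of the 4 values shown sits.

The compounds shown carry this fluoro only together with 2-(trifluoromethoxy)phenyl, so whether it shifts the number in the same direction with 4-bromo-2-fluorophenyl or 3-(trifluoromethyl)phenyl on the aromatic nitrogen stays open. Also open, as far as these compounds go, is whether chloro, methyl, methoxy or an amine on the same aromatic carbon would follow fluoro or return the number toward that of hydrogen.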